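This account rests on a few compounds, and the source may have more. Where it says the series, first, only, none or still open, it means among the compounds named here.

Series notes. Both measured compounds share one core and are read in a functional assay on GBM3 cells (Homo sapiens) for antiproliferative activity, read by WST assay, with a stated time of 72 h; on this read-out higher numbers stand for weaker inhibition and lower numbers for stronger inhibition. Compound 1 `O=C(Nc1ccccc1F)Nc1cc2ncncc2cc1OCc1cccc(F)c1` gives 8100 nM. Compound 2 `O=C(Nc1cccc(Cl)c1)Nc1cc2ncncc2cc1OCc1ccccc1` gives 6400 nM, the lowest of the two numbers, with compound 1 nearest and within the scatter, so no order between the two can be claimed.

The next step is compound 3 `O=C(Nc1ccccc1F)Nc1cc2ncncc2cc1OCc1ccccc1`, not yet measured in this assay. It differs from compound 2 in one place: 2-fluorophenyl in place of 3-chlorophenyl on an amide-type nitrogen.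

Among the measured compounds shown here, no step between measured compounds is known, so the size of this change has not been observed directly. The step from compound 2 to compound 3 is expected to be a 1.3-fold higher number from compound 2 to compound 3 (0.10 log units; within the scatter), i.e. little beyond the scatter, because compound 1, which also carries the 2-fluorophenyl group, gives 8100 nM. Compound 3 is therefore expected near 8000 nM, in the range 3500 nM to 18000 nM.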

Compound 3, half-maximal inhibitory concentration: 5900 nM
Compound 3: middle estimate off by 1.4-fold (0.13 log units), on the high side; low and high end bracket the measured number.
By their numbers in this assay, from the lowest: compounds 3, 2 and 1 (each within the scatter of the next).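

In this assay, among the compounds shown here, 2-fluorophenyl in place of 3-chlorophenyl on an amide-type nitrogen gives a 1.1-fold lower number from compound 2 to compound 3 (0.04 log units; within the scatter) and is the first direct reading at this position, where the two aryl groups cannot be told apart. Hydrogen in place of fluoro on an aromatic carbon gives a 1.4-fold lower number from compound 1 to compound 3 (0.14 log units; within the scatter) and likewise shows no step that can be separated from the scatter, so neither change yet marks a point in the series where the number responds. Nothing measured here offers an explanation for either step.

The compounds shown leave open whether any group on the amide-type nitrogen can move the number beyond the scatter. A phenyl ring carrying a dimethylamino group or a carboxylic acid, or a longer alkyl chain in place of the aryl ring, would test this.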